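Configuration change from compound 2 to compound 3

The source may hold more compounds than are shown below. What is called first, only, known or untested is meant among the compounds shown, and "the series" means these compounds.

For the measured compounds named here, compound 2 `Cc1cccc(NC(=O)N[C@H](C)c2ccccc2)c1` gives 47% in an ADME assay on the whole organism with Oryza sativa as the target, tested at 10 uM (a lower number here means a stronger effect, a higher number a weaker effect of the compound at the concentration tested), the lowest of the two numbers measured so far. Compound 1 `Cc1ccccc1NC(=O)N[C@H](C)c1ccccc1` gives 99% in this assay, a number that stands beyond the scatter above compound 2. Compound 3 `Cc1cccc(NC(=O)N[C@@H](C)c2ccccc2)c1` is not yet measured. How compound 3 differs from compound 2: the two compounds have the same atoms and bonds and differ only in configuration as drawn: 1 of 1 stereo elements differ; a stereocentre at a saturated chain carbon is drawn R in compound 2 and S in compound 3. Going by the values given here, no measured pair shows what such a change does, so the direction is open; a step of moderate size, somewhat more likely upward than downward, is expected. Compound 3 is therefore estimated at 65%, within 35% to 95%. The step expected is a number 18 percentage points higher from compound 2 to compound 3 (beyond the scatter).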

Compound 3, a percentage reported as activity, at one concentration (the size of the read-out at that concentration, not a potency): 100%
For compound 3 the middle estimate is 35 percentage points below the measured one, outside the stated range (above it).
By their numbers in this assay, from the lowest: compound 2; then compounds 1 and 3 (each within the scatter of the next).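

The stereocentre at the saturated chain carbon carries large weight in this assay: going from R to S gives a number 53 percentage points higher from compound 2 to compound 3 (beyond the scatter). Compounds 1 and 2 are both drawn R, so they gave no reading of this centre. The whole step can be assigned to the inversion because nothing else changes: the fact that compounds 2 and 3 differ only in the configuration as drawn.

Still open, going by these compounds, is whether the R form keeps the lower number when the methyl on the stereocentre gives way to a longer chain such as ethyl. Also open, on these data alone, is how an amine or a carboxylic acid on the shared core would behave in either configuration.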